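The compounds below may be only part of what the source reports. "The series", "measured", "known", "first", "only" and "open" are said of these compounds alone.

Measured in a functional assay on HCT-116 cells (Homo sapiens) for inhibition, read by CCK-8 assay, with a stated time of 48 h; on this read-out lower numbers stand for stronger inhibition and higher numbers for weaker inhibition:
- Compound 1 `COc1ccc(CN(C(=O)CSC(=S)N2CCN(C(=O)OC(C)(C)C)CC2)c2cc(OC)c(OC)c(OC)c2)cc1`: 620 nM.
- Compound 2 `COc1cc(N(Cc2ccc(Br)cc2)C(=O)CSC(=S)N2CCN(C(=O)OC(C)(C)C)CC2)cc(OC)c1OC`: 11400 nM.
- Compound 3 `COc1ccc(CN(C(=O)CSC(=S)N2CCN(C(=O)OC(C)(C)C)CC2)c2cc(OC)c(OC)c(OC)c2)cc1OC`: > 20000 nM.

Compound 3 has no number, only a limit of the assay: the limit of > 20000 nM in this assay, at which 1 of the 3 values shown sits.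

Compound 4 `COc1ccc(CN(C(=O)CSC(=S)N2CCN(C(=O)OC(C)(C)C)CC2)c2cc(OC)c(OC)c(OC)c2)cc1F` differs from compound 3 in one substituent: fluoro in place of methoxy on an aromatic carbon, ortho to a methoxy group and meta to a large group. This turns 3,4-dimethoxybenzyl into 3-fluoro-4-methoxybenzyl (fluoro in place of methoxy on an aromatic carbon).

Two measured steps on this ring bear on the change. Methoxy in place of hydrogen gave an at least 32-fold higher number from compound 1 to compound 3 (1.50 log units; beyond the scatter), a large loss, and this is the methoxy that compound 4 gives up. Bromo in place of methoxy gave an 18-fold higher number from compound 1 to compound 2 (1.26 log units; beyond the scatter), also large, so a single substituent change on this ring has moved the number well beyond the scatter in both cases.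

Compound 4 sits structurally between compound 1 and compound 3, so a partial return towards compound 1 at 620 nM is expected, though not a full one. The expected step is an at least 8.0-fold lower number from compound 3 to compound 4 (0.90 log units; beyond the scatter), towards stronger inhibition in this assay. For compound 4 the estimated value is 2500 nM, with an expected range of 600 nM to 15000 nM.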

Compound 4, half-maximal inhibitory concentration: 8210 nM
For compound 4 the middle estimate is 3.3-fold (0.52 log units) below the measured one, within the range that was stated.
By their numbers in this assay, from the lowest: compound 1; then compounds 4 and 2 (each within the scatter of the next). At a limit, above all of these: compound 3.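

In this assay, fluoro in place of methoxy on this aromatic carbon recovers part of the inhibition, with an at least 2.4-fold lower number from compound 3 to compound 4 (0.38 log units; beyond the scatter), and the size of that step is only a floor. Compound 3 has no number, only a limit of the assay: the limit of > 20000 nM in this assay, at which 1 of the 4 values shown sits.

Fluoro on this carbon is still far from the unsubstituted ring, with a 13-fold higher number from compound 1 to compound 4 (1.12 log units; beyond the scatter), so even this one-atom group carries a large cost relative to hydrogen, and the 3-fluoro-4-methoxyphenyl and 4-bromophenyl variants cannot be told apart, with a 1.4-fold lower number from compound 2 to compound 4 (0.14 log units; within the scatter).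

The compounds shown leave open how other groups on this aromatic carbon would compare, for example chloro, hydroxy or an amine, and so whether any group here can match hydrogen in compound 1. Also open is how far the 4-methoxy group itself matters when this carbon carries fluoro, since the only change shown at that methoxy is bromo, and that change was made on the ring of compound 1, which has hydrogen on this carbon.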